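Benzoxazole anilides: cytotoxicity on HepG2 cells

The compounds below may be only part of what the source reports. "The series", "measured", "known", "first", "only" and "open" are said of these compounds alone.

Measured so far:
compound 1 `Cc1cc(-c2nc3cc(Cl)ccc3o2)ccc1NC(=O)CN1CCN(CCCN(C)C)CC1` — 11200 nM
compound 2 `Cc1cc(-c2nc3cc(Cl)ccc3o2)ccc1NC(=O)CCl` — 35000 nM
compound 3 `Cc1ccc2oc(-c3ccc(NC(=O)CN4CCN(CCCN(C)C)CC4)c(C)c3)nc2c1` — 5650 nM

In a functional assay on HepG2 cells (Homo sapiens) for cytotoxicity, read by MTT assay, with a stated time of 24 h (on this read-out higher numbers stand for weaker inhibition and lower numbers for stronger inhibition), compound 1 gives 11200 nM and compound 3 gives 5650 nM. Between them the change is methyl in place of chloro on an aromatic carbon and the step is a 2.0-fold lower number from compound 1 to compound 3 (0.30 log units; within the scatter). Compound 2 gives 35000 nM, the highest number of the three; the difference between its core and that of compound 1 is not broken down here.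

Compound 4 `Cc1ccc2oc(-c3ccc(NC(=O)CCl)c(C)c3)nc2c1` is not yet measured in this assay. It differs from compound 2 by methyl in place of chloro on an aromatic carbon, the same change as from compound 1 to compound 3. For compound 4 the step of a 1.8-fold lower number from compound 2 to compound 4 (0.24 log units; within the scatter) is expected, resting on the step of a 2.0-fold lower number from compound 1 to compound 3 (0.30 log units; within the scatter) in this assay and on compound 2 at 35000 nM. Compound 4 is therefore estimated at 20000 nM, with a range from 9000 nM to 45000 nM.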

Compound 4, half-maximal inhibitory concentration: 54800 nM
The estimate for compound 4 lay 2.7-fold (0.44 log units) below the measured number; the whole stated range lies below it.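

On the core of compound 2, methyl in place of chloro on an aromatic carbon gives a 1.6-fold higher number from compound 2 to compound 4 (0.19 log units; within the scatter). Set beside the earlier step, the same change does not carry over unchanged from the core of compound 1 to the core of compound 2: the same change on two cores in this assay, a 2.0-fold lower number (0.30 log units; within the scatter) from compound 1 to compound 3 and a 1.6-fold higher number (0.19 log units; within the scatter) from compound 2 to compound 4, 3.1-fold (0.49 log units) apart, beyond the scatter of two such steps. Each step alone stays within the scatter, so neither shows an effect of the change on its own core, and two pairs cannot show which feature of the cores sets the steps apart.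

Open, as far as these compounds go, is whether another group on the same aromatic carbon, such as fluoro or methoxy, would follow either step. Also open, from the compounds shown here alone, is how the change behaves with a simple amine or a carboxylic acid in place of the side chain of compound 1.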